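The source may hold more compounds than are shown below. What is called first, only, known or untested is meant among the compounds shown, and "the series" means these compounds.

Measured so far:
compound 1 `O=C(O)c1ccc(CN2CCC[C@H](OCc3cc(Cl)cc(Cl)c3)[C@@H]2c2ccccc2)s1`
compound 2 `Clc1cc(Cl)cc(CO[C@H]2CCCN(Cc3nccs3)[C@H]2c2ccccc2)c1`

In an assay on isolated protein for activation of cGMP-dependent protein kinase 1 (Homo sapiens), read by ADP-Glo, with stated times of 120 min and 40 min (on this read-out lower numbers stand for an effect already at smaller amounts and higher numbers for an effect only at larger amounts of compound), compound 1 gives 76000 nM. For compound 2 this assay returns only a limit, > 200000 nM, and no number. Among the compounds with values here, the one measured step, an at least 2.6-fold higher number from compound 1 to compound 2 (0.42 log units; beyond the scatter), is itself bounded by that limit, as the limit of > 200000 nM in this assay, at which 1 of the 2 values shown sits, shows, so compound 2 sits at the weak end of what this assay can report.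

Compound 3 `Clc1cc(Cl)cc(CO[C@H]2CCCN(Cc3ncc[nH]3)[C@H]2c2ccccc2)c1` differs from compound 2 by 1H-imidazol-2-yl in place of 1,3-thiazol-2-yl on a saturated chain carbon bound to an amine nitrogen in a ring. Within the data shown here, no measured step covers this change; the single known step concerns a different group on the same saturated chain carbon, and it only points toward the limit. There is therefore no ground to expect compound 3 to move away from where compound 2 stands. The step is expected to be a step that the limit leaves unreadable from compound 2 to compound 3, nothing beyond the usual scatter, most likely ending again at the limit. The estimate for compound 3 is 250000 nM, with a range from 80000 nM to 800000 nM.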

Compound 3, half-maximal effective concentration: 47000 nM
Compound 3: middle estimate off by 5.3-fold (0.73 log units), on the high side; the measured number lies below the stated range.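

On the saturated chain carbon bound to an amine nitrogen in a ring, the choice of five-membered ring decides whether a compound gives a number at all in this assay: 1H-imidazol-2-yl in place of 1,3-thiazol-2-yl gives an at least 4.2-fold lower number from compound 2 to compound 3 (0.62 log units; beyond the scatter). A carboxy group is also not needed for a readable value, since a 1.6-fold lower number from compound 1 to compound 3 (0.21 log units; within the scatter) leaves compound 1 and compound 3 indistinguishable. The true size of the first step cannot be read because compound 2 carries only a limit: the limit of > 200000 nM in this assay, at which 1 of the 3 values shown sits.

The compounds shown do not tell whether the hydrogen-bond donor of 1H-imidazol-2-yl is what separates it from 1,3-thiazol-2-yl. From the compounds shown here alone, how an amide or an open-chain amine would read on that same carbon also stays open.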